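The source may hold more compounds than are shown below. What is called first, only, known or untested is meant among the compounds shown, and "the series" means these compounds.

Compound 1 `CC1=CS[C@@](O)(c2ccc(Cl)cc2)c2noc(=O)n21` and compound 2 `CC1=CS[C@@](O)(c2ccc(Br)cc2)c2noc(=O)n21` share one core and differ only in the halogen on the aryl ring. In a functional assay (Cavia porcellus) with Rattus norvegicus as the target (on this read-out higher numbers stand for an effect only at larger amounts of compound and lower numbers for an effect already at smaller amounts), compound 1 gives 800 nM, while compound 2 gives 320 nM. The change bromo in place of chloro on an aromatic carbon therefore reads a 2.5-fold lower number from compound 1 to compound 2 (0.40 log units; beyond the scatter). Compound 3 `CCCCCCOC1(c2ccc(Cl)cc2)SC=C(C)n2c1noc2=O` carries a different core; the difference between the two cores is not broken down here. In this assay compound 3 gives 640 nM, which sits close to compound 1. Compound 4 `CCCCCCOC1(c2ccc(Br)cc2)SC=C(C)n2c1noc2=O` has not yet been measured; it is related to compound 3 by bromo in place of chloro on an aromatic carbon, the same change as between compound 1 and compound 2. On the strength of the observed step of a 2.5-fold lower number from compound 1 to compound 2 (0.40 log units; beyond the scatter), compound 4 is expected to show a step of a 2.1-fold lower number from compound 3 to compound 4 (0.33 log units; beyond the scatter). Compound 4 is therefore estimated at 300 nM, within a range from 150 nM to 600 nM.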

Compound 4, half-maximal effective concentration: 830 nM
Beside the measured number, compound 4's estimate is 2.8-fold (0.44 log units) below it; measured number above the stated range.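

In this assay, bromo in place of chloro on the core of compound 3 gives a 1.3-fold higher number from compound 3 to compound 4 (0.11 log units; within the scatter), so the shift seen on the core of compound 1 does not reappear here. The change therefore cannot be carried unchanged from one of these cores to the other: the same change on two cores in this assay, a 2.5-fold lower number (0.40 log units; beyond the scatter) from compound 1 to compound 2 and a 1.3-fold higher number (0.11 log units; within the scatter) from compound 3 to compound 4, 3.2-fold (0.51 log units) apart, beyond the scatter of two such steps. With one pair on each core, this does not show which difference between the cores matters, nor how the change would read on any further core.

As far as these compounds go, whether fluoro or methoxy in place of the halogen would follow either core remains open. Also open, from the compounds shown here alone, is how a shorter chain or an amine in place of the hexyl ether of compound 3 would affect the step.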